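A few compounds are considered here, and "the series" means these few. Any claim that something is new, unique, unknown or untested is made for them only; others in the source may bear on it.

In a functional assay on A-431 cells (Homo sapiens) for antiproliferative activity, read by sulforhodamine B assay, with a stated time of 72 h (a higher number here means a weaker inhibitor, a lower number a stronger inhibitor), compound 1 (`C=C1CC(CBr)(c2ccccc2)OC1=O`) gives 1480 nM and compound 2 (`C=C1CC(C(Br)c2ccccc2)OC1=O`) gives 20300 nM as the higher of the two numbers, a gap beyond the usual scatter. Compound 3 (`C=C1CC(c2ccccc2)(C(Br)c2ccccc2)OC1=O`) differs from compound 2 by a single change, phenyl in place of hydrogen on a saturated ring carbon. Among the measured compounds shown here, no measured pair shows this change alone, so its size in this assay remains open. Compound 1 also carries a phenyl on that ring carbon and gives 1480 nM as its number, which points to a moderate move toward a lower number rather than none. The step expected is a 3.4-fold lower number from compound 2 to compound 3 (0.53 log units; beyond the scatter) by this estimate. Compound 3 is expected at 6000 nM (1500 nM to 25000 nM as the estimated range).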

Compound 3, half-maximal inhibitory concentration: 4190 nM
Compound 3: middle estimate off by 1.4-fold (0.16 log units), on the high side; the measured number falls inside the stated range.
By their numbers in this assay, from the lowest: compound 1; then compound 3; then compound 2.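

In this assay, among the compounds shown here, phenyl in place of hydrogen on the saturated ring carbon next to the ring oxygen gives a 4.8-fold lower number from compound 2 to compound 3 (0.69 log units; beyond the scatter) as the first measured reading of this change alone. Phenyl in place of hydrogen on the saturated chain carbon bound to a bromine atom and a saturated ring carbon runs the other way, with a 2.8-fold higher number from compound 1 to compound 3 (0.45 log units; beyond the scatter) beyond the scatter as well, so across these three compounds the direction of the step differs between the two carbons. Nothing at hand gives a reason for either step.

On these data alone, it remains open whether a methyl or a longer chain on the ring carbon would give a step like that of phenyl, or whether a phenyl bearing a methoxy group or an amine would shift the number further. The compounds also leave open how these steps would read with chlorine or a hydroxyl group in place of the bromine atom.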